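Series notes: configuration at the pyrrolidine stereocentre

The source may hold more compounds than are shown below. What is called first, only, known or untested is meant among the compounds shown, and "the series" means these compounds.

Compound 2 `CC(C)(C)OC(=O)N1CCC[C@H]1C(=O)N1CCC(NS(=O)(=O)c2cc(S(=O)(=O)c3ccccc3)ccc2C(F)(F)F)CC1` holds the lowest number of the two measured; in a functional assay on U2OS cells for antagonist activity at proto-oncogene Wnt-3 (Homo sapiens), read by a luciferase reporter, with a stated time of 18 h (a lower number here means that less compound is needed, a higher number that more compound is needed for the effect), compound 2 gives 60 nM, while compound 1 `O=C(CN1CCCC1)N1CCC(NS(=O)(=O)c2cc(S(=O)(=O)c3ccccc3)ccc2C(F)(F)F)CC1` gives 190 nM. Going by the values given here, the only measured step, a 3.2-fold lower number from compound 1 to compound 2 (0.50 log units; beyond the scatter), concerns a change of the whole acyl group and says nothing about configuration. Compound 3 `CC(C)(C)OC(=O)N1CCC[C@@H]1C(=O)N1CCC(NS(=O)(=O)c2cc(S(=O)(=O)c3ccccc3)ccc2C(F)(F)F)CC1` differs from compound 2 only thus: the two compounds have the same atoms and bonds and differ only in configuration as drawn: 1 of 1 stereo elements differ; a stereocentre at a saturated ring carbon is drawn S in compound 2 and R in compound 3. Among the compounds with values here, no measured step bears on this change, so the direction is open; a modest rise in the number, a 2.2-fold higher number from compound 2 to compound 3 (0.34 log units; beyond the scatter), is expected. For compound 3 the estimate in this assay is 130 nM, within 40 nM to 450 nM.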

Compound 3, half-maximal effective concentration: 210 nM
Compound 3: the middle estimate sits 1.6-fold (0.21 log units) below what was measured; low and high end bracket the measured number.
By their numbers in this assay, from the lowest: compound 2; then compounds 1 and 3 (each within the scatter of the next).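

In this assay the configuration at the pyrrolidine stereocentre matters, with S as drawn giving the lower number: a 3.5-fold higher number from compound 2 to compound 3 (0.54 log units; beyond the scatter). This gap can be assigned to that stereocentre alone, because of one fact: the fact that compounds 2 and 3 differ only in the configuration as drawn. Going by these compounds alone, the advantage of the 1-(tert-butoxycarbonyl)pyrrolidin-2-yl group over (pyrrolidin-1-yl)methyl is seen only with S, as the R form shows no separation: a 1.1-fold higher number from compound 1 to compound 3 (0.04 log units; within the scatter).

Going by these compounds, whether S still gives the lower number with a free amine or an acetyl amide in place of the tert-butoxycarbonyl group remains open.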